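This account rests on a few compounds, and the source may have more. Where it says the series, first, only, none or still open, it means among the compounds named here.

Of the compounds shown here, three that share one core have been measured in an ADME assay on cells (spleen, Mus musculus, strain C57BL/6) for inhibition, read by flow cytometry and propidium iodide staining, with a stated time of 24 h, at 37 degrees C; a higher number here means that more compound is needed for the effect, a lower number that less compound is needed. Compound 1 `CCC(O)Cc1cn(CC(=O)NCc2ccccc2)nn1` gives 630 uM in this assay, the lowest of the three numbers. Compound 2 `CC(C)(O)c1cn(CC(=O)NCc2ccccc2)nn1` gives 1600 uM in this assay, and compound 3 `Nc1cccc(-c2cn(CC(=O)NCc3ccccc3)nn2)c1` gives 800 uM in this assay. Among the measured steps, a 2.5-fold higher number from compound 1 to compound 2 (0.40 log units; beyond the scatter), whereas a 1.3-fold higher number from compound 1 to compound 3 (0.10 log units; within the scatter).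

Compound 4 `Cc1ccc(-c2cn(CC(=O)NCc3ccccc3)nn2)cc1` has not yet been measured in this assay. It differs from compound 1 in one place: 4-methylphenyl in place of 2-hydroxybutyl on an aromatic carbon. For the measured compounds named here, the step that bears most on this change is the one from compound 1 to compound 3, where the same 2-hydroxybutyl group gave way to another substituted phenyl group, 3-aminophenyl, and a 1.3-fold higher number from compound 1 to compound 3 (0.10 log units; within the scatter). The step to compound 2, with a 2.5-fold higher number from compound 1 to compound 2 (0.40 log units; beyond the scatter), involved a small hydroxyl-bearing group rather than a ring, so it speaks less directly to compound 4. A step of no more than modest size, if any, is therefore expected here.

Compound 4 is expected to give about 750 uM in this assay, within a range from 320 uM to 1800 uM. That estimate corresponds to an expected 1.2-fold higher number from compound 1 to compound 4 (0.08 log units; within the scatter), which is expected to remain within the scatter.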

Compound 4, concentration for half-maximal effect: "non-toxic" (no number reported)
No number was reported for compound 4; no gap can be computed for the estimate.
By their numbers in this assay, from the lowest: compounds 1, 3 and 2 (each within the scatter of the next, the first and the last beyond it).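

In this assay, for the compounds shown here, compound 4 is reported only as non-toxic, without a number, so no step from compound 1 or any other compound to compound 4 can be read. No evidence on the cause of this result is available. From the compounds shown here alone, how 4-methylphenyl compares numerically with 2-hydroxybutyl remains open.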